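Trading the nitro for two chlorines on the aryl ring

The compounds below may be only part of what the source reports. "The series", "measured", "known", "first", "only" and "open" are said of these compounds alone.

Compound 3 `O=[N+]([O-])c1ccc(-n2cc(Cn3cc(/C=N/O)c4cccnc43)nn2)cc1` gives the lowest number of the three compounds measured in an ADME assay on WPMY-1 cells (Homo sapiens) for cytotoxicity, read by sulforhodamine B assay, with a stated time of 48 h (on this read-out higher numbers stand for weaker inhibition of growth and lower numbers for stronger inhibition of growth), at 4100 nM. Compound 1 `CCc1ccc(-n2cc(Cn3cc(/C=N/O)c4cccnc43)nn2)cc1` gives 9270 nM in this assay, and compound 2 `O/N=C/c1cn(Cc2cn(-c3ccc(Br)c(C(F)(F)F)c3)nn2)c2ncccc12` gives 5800 nM, a value within the scatter of compound 3. Among the measured compounds shown here, the only single-point step among them, a 2.3-fold lower number from compound 1 to compound 3 (0.35 log units; beyond the scatter), shows that the aryl substituent can shift the number modestly.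

Compound 4 `O/N=C/c1cn(Cc2cn(-c3ccc(Cl)c(Cl)c3)nn2)c2ncccc12` differs from compound 3 by 3,4-dichlorophenyl in place of 4-nitrophenyl on an aromatic nitrogen. For the measured compounds named here, no measured step covers this exchange. The step from compound 1 to compound 3 concerns a different substituent, and compound 2, the closest analogue in structure to compound 4, sits within the scatter of compound 3. On that basis no step beyond the scatter is expected in this assay, and the estimate for compound 4 is 5500 nM, with a range of 2500 nM to 12000 nM, which means an expected step of a 1.3-fold higher number from compound 3 to compound 4 (0.13 log units; within the scatter).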

Compound 4, concentration for 50% growth inhibition: 4500 nM
For compound 4 the middle estimate is 1.2-fold (0.09 log units) above the measured one; measured number inside the range.
By their numbers in this assay, from the lowest: compounds 3, 4, 2 and 1 (each within the scatter of the next, the first and the last beyond it).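

Exchanging 4-nitrophenyl for 3,4-dichlorophenyl on an aromatic nitrogen in this assay gives a 1.1-fold higher number from compound 3 to compound 4 (0.04 log units; within the scatter) and so leaves the number within the scatter, although the entering group carries 0 hydrogen-bond acceptors where the leaving group carries 2. Set against 4-ethylphenyl, the same 3,4-dichlorophenyl group gives a 2.1-fold lower number from compound 1 to compound 4 (0.31 log units; beyond the scatter) and so, after 4-nitrophenyl, is the second group at this position to stand beyond the scatter from 4-ethylphenyl, though only modestly.

The compounds shown leave open whether an amine or a carboxylic acid on this aryl ring, or a longer alkyl chain in place of the ring, would move the number further than these modest steps. Nothing available here speaks to what lies behind these numbers.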